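Phenyl in place of benzyl on the ring nitrogen

A few compounds are considered here, and "the series" means these few. Any claim that something is new, unique, unknown or untested is made for them only; others in the source may bear on it.

Compound 1, `CCCn1c(=O)[nH]c2nc(-c3ccc(S(=O)(=O)N4CCN(c5ccc(C)cc5)CC4)cc3)[nH]c2c1=O`, in an assay on CHO cells for displacement of a labelled ligand from adenosine receptor A1 (Homo sapiens), read by scintillation counting, with a stated time of 90 min, in the presence of a further agent that is not named here; on this read-out higher numbers stand for weaker inhibition and lower numbers for stronger inhibition: compound 1 gives > 1000 nM, a limit of the assay.
Compound 2, `CCCn1c(=O)[nH]c2nc(-c3ccc(S(=O)(=O)N4CCN(c5cccc(F)c5)CC4)cc3)[nH]c2c1=O`, in this assay: compound 2 gives > 1000 nM, also a limit.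
Compound 3, `CCCn1c(=O)[nH]c2nc(-c3ccc(S(=O)(=O)N4CCN(Cc5ccc(Br)c(F)c5)CC4)cc3)[nH]c2c1=O`, in this assay: compound 3 gives 326 nM.

Within the data shown here, compound 3 carries the only number among the three; the other two values sit at the limit of > 1000 nM in this assay, at which 2 of the 3 values shown sit. Compound 4, `CCCn1c(=O)[nH]c2nc(-c3ccc(S(=O)(=O)N4CCN(c5ccccc5)CC4)cc3)[nH]c2c1=O`, differs from compound 3 in one place: phenyl in place of 4-bromo-3-fluorobenzyl on an amine nitrogen in a ring. The measured steps that bear on this are an at least 3.0-fold lower number from compound 1 to compound 3 (0.48 log units; beyond the scatter) and an at least 3.0-fold lower number from compound 2 to compound 3 (0.48 log units; beyond the scatter), both going from an aryl group on the ring nitrogen to the benzyl group. Compound 4 reverses that direction, so a step back toward the limit is expected, a 4.6-fold higher number from compound 3 to compound 4 (0.66 log units; beyond the scatter). Compound 4 is estimated at 1500 nM, within 500 nM to 5000 nM, with a limit rather than a number the likelier outcome.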

Compound 4, inhibition constant: 364 nM
Estimate against measurement, compound 4: 4.1-fold (0.61 log units) above, and the stated range ends above it.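

Swapping 4-bromo-3-fluorobenzyl for phenyl on the amine nitrogen in the ring gives a 1.1-fold higher number from compound 3 to compound 4 (0.05 log units; within the scatter) in this assay, so a benzyl group is not required at this position. The substituent on the phenyl counts instead: hydrogen in place of methyl gives an at least 2.7-fold lower number from compound 1 to compound 4 (0.43 log units; beyond the scatter), and hydrogen in place of fluoro gives an at least 2.7-fold lower number from compound 2 to compound 4 (0.43 log units; beyond the scatter). Those two steps are open-ended, as compound 1 and compound 2 stand at a limit and not a number: the limit of > 1000 nM in this assay, at which 2 of the 4 values shown sit.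

On these data alone, how an unsubstituted benzyl group compares with phenyl remains open. So does whether a methoxy or chloro group on the phenyl follows methyl and fluoro.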